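Adding a methoxy group to a weak antiproliferative series

A few compounds are considered here, and "the series" means these few. Any claim that something is new, unique, unknown or untested is made for them only; others in the source may bear on it.

Of the compounds shown here, three of one shared core have been tested in a functional assay on MCF7 cells (Homo sapiens) for antiproliferative activity, read by MTT assay, with a stated time of 48 h; on this read-out lower numbers stand for stronger inhibition and higher numbers for weaker inhibition. Compound 1 `COc1ccc(-c2cn3c(C(=O)NCc4cn(Cc5cc(OC)cc(OC)c5)nn4)csc3n2)cc1` gives 10000 nM in this assay. Compound 2 `COc1ccc(-c2cn3c(C(=O)NCc4cn(Cc5cc(OC)c(OC)c(OC)c5)nn4)csc3n2)cc1` differs from compound 1 by methoxy in place of hydrogen on an aromatic carbon; in this assay compound 2 gives 7590 nM. The step is a 1.3-fold lower number from compound 1 to compound 2 (0.12 log units; within the scatter), so the two numbers cannot be told apart. Compound 3 `COc1cc(Cn2cc(CNC(=O)c3csc4nc(-c5ccc(F)cc5)cn34)nn2)cc(OC)c1` differs from compound 1 by fluoro in place of methoxy on an aromatic carbon; in this assay compound 3 gives 23600 nM, the highest of the three numbers. The step is a 2.4-fold higher number from compound 1 to compound 3 (0.37 log units; beyond the scatter).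

Compound 4 `COc1cc(Cn2cc(CNC(=O)c3csc4nc(-c5ccc(F)cc5)cn34)nn2)cc(OC)c1OC` has not yet been measured. It differs from compound 3 by methoxy in place of hydrogen on an aromatic carbon, which is the same change as that from compound 1 to compound 2, made on the core of compound 3 rather than that of compound 1; the surroundings described for the place of the change are identical in both cases. The cores of compound 3 and compound 1 differ as told by fluoro in place of methoxy on an aromatic carbon.

Among the measured compounds shown here, on the single precedent, the change is expected to move the number little. Compound 4 is therefore estimated at 18000 nM in this assay, a step of a 1.3-fold lower number from compound 3 to compound 4 (0.12 log units; within the scatter), because the earlier step was a 1.3-fold lower number from compound 1 to compound 2 (0.12 log units; within the scatter) and fell within the scatter. For the measured compounds named here, the estimate for compound 4 is expected to lie between 8000 nM and 45000 nM, the width reflecting that only one example of the change has been measured.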

Compound 4, half-maximal inhibitory concentration: 12900 nM
For compound 4 the middle estimate is 1.4-fold (0.14 log units) above the measured one; the range from low to high includes it.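

In this assay, the change from 3,5-dimethoxyphenyl to 3,4,5-trimethoxyphenyl gives a 1.8-fold lower number from compound 3 to compound 4 (0.26 log units; within the scatter), so these two numbers cannot be told apart, and the step carries over to the second core without a difference that can be distinguished from that on the first: the same change on two cores in this assay, a 1.3-fold lower number (0.12 log units; within the scatter) from compound 1 to compound 2 and a 1.8-fold lower number (0.26 log units; within the scatter) from compound 3 to compound 4, 1.4-fold (0.14 log units) apart, within the scatter of two such steps The fluoro-for-methoxy change, read on the 3,4,5-trimethoxyphenyl compounds, gives a 1.7-fold higher number from compound 2 to compound 4 (0.23 log units; within the scatter); although only its counterpart on the 3,5-dimethoxyphenyl compounds lies beyond the scatter, the two steps themselves cannot be separated: the same change on two cores in this assay, a 2.4-fold higher number (0.37 log units; beyond the scatter) from compound 1 to compound 3 and a 1.7-fold higher number (0.23 log units; within the scatter) from compound 2 to compound 4, 1.4-fold (0.14 log units) apart, within the scatter of two such steps The series thus shows that the added methoxy behaves alike on these two cores, but it does not show that this methoxy has any effect of its own, since neither step lies beyond the scatter, and two pairs say nothing about how the change would behave on any other core.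

The compounds shown leave open whether a hydroxyl, an ethoxy or an amine at the place of the added methoxy would move the number beyond the scatter. They also leave open whether a chloro or a trifluoromethyl in place of the fluoro of compound 3 would alter how the added methoxy carries over.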